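This account rests on a few compounds, and the source may have more. Where it says the series, first, only, none or still open, it means among the compounds named here.

Of the compounds shown here, three sharing one core have been measured in an assay on cells for inhibition of Polyunsaturated fatty acid 5-lipoxygenase (Homo sapiens), read by HPLC, with stated times of 15 min and 10 min; a higher number here means a weaker inhibitor, a lower number a stronger inhibitor. Compound 1 `Cc1ccc2nc(-c3ccc(N(C)C)cc3)c(NC3CCCCC3)n2c1` gives 600 nM, the lowest of the three numbers. Among the measured compounds shown here, compound 3 `Cc1ccc2nc(-c3ccc([N+](=O)[O-])cc3)c(NC3CCCCC3)n2c1` gives 1530 nM; the step of a 2.6-fold higher number from compound 1 to compound 3 (0.41 log units; beyond the scatter) is the only single-point change among the measured compounds. Compound 2 `COc1cccc(-c2nc3ccc(C)cn3c2NC2CCCCC2)c1` gives 1220 nM, the second highest number of the three: it stands within the scatter of compound 3 and beyond the scatter of compound 1, whose number is lower.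

Compound 4 `Cc1ccc2nc(-c3ccccc3O)c(NC3CCCCC3)n2c1` differs from compound 2 by 2-hydroxyphenyl in place of 3-methoxyphenyl on an aromatic carbon. For the measured compounds named here, no measured step makes this same change. Going by the values given here, the step from compound 1 to compound 3 alters a group on the same aryl ring and is modest in size, which is the only guide to how much this ring position moves the number. On that basis a step of modest size at most is expected in this assay, and its direction cannot be read from the three measured compounds; the estimated step of a 1.1-fold lower number from compound 2 to compound 4 (0.04 log units; within the scatter) is therefore set close to zero. Compound 4 is expected to give about 1100 nM in this assay, with a range from 400 nM to 3500 nM.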

Compound 4, half-maximal inhibitory concentration: 1900 nM
Compound 4: middle estimate off by 1.7-fold (0.24 log units), on the low side; measured number inside the range.
By their numbers in this assay, from the lowest: compound 1; then compounds 2, 3 and 4 (each within the scatter of the next).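

In this assay, replacing 3-methoxyphenyl with 2-hydroxyphenyl on this aromatic carbon gives a 1.6-fold higher number from compound 2 to compound 4 (0.19 log units; within the scatter), a step that stays within the scatter even though the entering group has 1 hydrogen-bond donor and the leaving group has 0 hydrogen-bond donors. Among the compounds shown here, until now, the only measured change at this place was the swap of dimethylamino for nitro on the aryl ring, a 2.6-fold higher number from compound 1 to compound 3 (0.41 log units; beyond the scatter), which lies beyond the scatter, so the new step shows that not every change of the aryl group here moves the number measurably. Nothing available explains why this change has so little effect while the earlier one has more.

The new step changes both the oxygen-bearing group and its place on the aryl ring, so the compounds shown cannot separate these two changes; 3-hydroxyphenyl or 2-methoxyphenyl would be needed to tell them apart. They also leave open how the number responds to a carboxylic acid or a primary amine on the aryl ring, and to a longer chain in place of the cyclohexylamino group, which all the compounds shown share.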